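The source may report more compounds than this note shows. Statements on the series, on what has been measured and on what is new or still open speak of the compounds shown alone.

Working notes on the series. In a functional assay on MCF7 cells (Homo sapiens) for inhibition, read by sulforhodamine B assay, with a stated time of 48 h (on this read-out higher numbers stand for weaker inhibition of growth and lower numbers for stronger inhibition of growth), compound 1 (`O=C1CC(c2ccc(Cl)cc2)Nc2c(Br)cc(Br)cc21`) gives 146 nM and compound 2 (`O=C1CC(c2ccc(Br)cc2)Nc2c(Br)cc(Br)cc21`) gives 151 nM. Among the compounds with values here, exchanging chloro for bromo on the aromatic carbon amounts to a 1.0-fold higher number from compound 1 to compound 2 (0.01 log units; within the scatter), so compound 2 stands level with compound 1 on the only two numbers available.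

The next change leads to compound 3 (`O=C1CC(c2ccc(O)cc2)Nc2c(Br)cc(Br)cc21`): hydroxy in place of bromo on an aromatic carbon. This places hydroxy in place of bromo on an aromatic carbon, para to a large group. Within the data shown here, the chloro-to-bromo exchange is the only measured step that bears on this change, and it involves no hydroxy compound. The data therefore give no direct size for the new step, and its flat result cannot simply be carried over to a group of a different kind. A step towards weaker growth inhibition is tentatively expected, with low confidence in its direction. The estimated change in this assay is a 2.1-fold higher number from compound 2 to compound 3 (0.33 log units; beyond the scatter). Compound 3 is expected at 320 nM, with an estimated range from 80 nM to 1200 nM.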

Compound 3, concentration for 50% growth inhibition: < 100 nM
Compound 3: no number, only a limit; the forecaster's own chance of this, stated with the estimate: 5%; at least 3.2-fold (0.50 log units) between middle value and limit.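

In this assay compound 3 gives < 100 nM as a limit of the assay and not as a number. The halogen exchange (a 1.0-fold higher number from compound 1 to compound 2 (0.01 log units; within the scatter)) tested only one halogen against another, whereas hydroxy brings a hydrogen-bond donor and a hydrogen-bond acceptor to this aromatic carbon, and the steps that can be read (an at least 1.5-fold lower number from compound 2 to compound 3 (0.17 log units; that floor lies within the scatter)) and (an at least 1.4-fold lower number from compound 1 to compound 3 (0.16 log units; that floor lies within the scatter)) show no weakening of growth inhibition, although both floors lie within the scatter. This position, para to a large group, therefore tolerates a group of a different kind from the halogens, while the size of the gain stays unknown and the reading rests on a single limit: the limit of < 100 nM in this assay, at which 1 of the 3 values shown sits.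

The compounds shown leave open how far the true value of compound 3 lies from its limit, and whether methoxy or an amine on the same carbon would behave as hydroxy does. They also leave open whether the same exchange would hold if the two bromo groups on the shared core were replaced.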